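The compounds below may be only part of what the source reports. "The series", "measured", "known", "first", "only" and "open" are said of these compounds alone.

Measured compounds:
compound 1, `C/C(CN)=C(/F)CN(C[C@H]1Cc2ccccc2CN1)[C@H]1CCCc2cccnc21`: 44 nM
compound 2, `FC1(F)CCC(NC/C=C\CN(C[C@H]2Cc3ccccc3CN2)[C@H]2CCCc3cccnc32)CC1`: 98 nM

In a functional assay on CCRF-CEM cells for antagonist activity at C-X-C chemokine receptor type 4 (Homo sapiens), read by calcium flux, with stated times of 25 min and 90 s (a higher number here means a weaker inhibitor, a lower number a stronger inhibitor), compound 1 gives 44 nM, the lower of the two numbers recorded. Compound 2 gives 98 nM in this assay, and the gap between the two values lies beyond the usual scatter. Compound 3, `N[C@H]1CC[C@@H](N(C[C@H]2Cc3ccccc3CN2)[C@H]2CCCc3cccnc32)CC1`, has not yet been measured. It differs from compound 1 in one place: 4-aminocyclohexyl in place of 3-(aminomethyl)-2-fluorobut-2-en-1-yl on an amine nitrogen. Both the group that leaves and the group that enters carry one hydrogen-bond donor and one hydrogen-bond acceptor, but the entering group is a six-membered non-aromatic ring of carbon only with two defined stereocentres, while the leaving group has no ring and one double bond outside aromatic rings. For the measured compounds named here, no pair of measured compounds tracks a change of this kind, so there is no direct guide. A small step toward a higher number is expected, a 1.5-fold higher number from compound 1 to compound 3 (0.17 log units; within the scatter), near the edge of the scatter. Compound 3 is estimated at 65 nM, with a range from 15 nM to 280 nM.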

Compound 3, half-maximal inhibitory concentration: 1800 nM
The estimate for compound 3 lay 28-fold (1.44 log units) below the measured number; the measured number lies above the stated range.
By their numbers in this assay, from the lowest: compound 1; then compound 2; then compound 3.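

In this assay, 4-aminocyclohexyl in place of 3-(aminomethyl)-2-fluorobut-2-en-1-yl on an amine nitrogen brings a 41-fold higher number from compound 1 to compound 3 (1.61 log units; beyond the scatter), a large step. The number at this position is thus highly sensitive to the identity of the group, even though the two groups match in heavy atoms and in hydrogen-bond donors and acceptors; they differ in the ring, the double bond, the fluorine and the defined stereocentres. Nothing measured here explains the step.

The compounds shown do not separate the contributions of the ring, the double bond, the fluorine and the stereocentres. Going by these compounds, how a saturated 4-aminobutyl chain or a 4-(aminomethyl)cyclohexyl group on the same nitrogen would compare with either group remains open.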